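Swapping two halogens on the sulfonamide phenyl group

A few compounds are considered here, and "the series" means these few. Any claim that something is new, unique, unknown or untested is made for them only; others in the source may bear on it.

Compound 1 `O=S(=O)(Nc1ccc(Cl)c(Cl)c1)c1ccc(-c2cnc(C3CC3)o2)cc1`: 416 nM
Compound 2 `O=S(=O)(Nc1ccccc1Cl)c1ccc(-c2cnc(C3CC3)o2)cc1`: 429 nM
Compound 3 `O=S(=O)(Nc1ccc(F)c(Cl)c1)c1ccc(-c2cnc(C3CC3)o2)cc1`: 260 nM

These values come from a functional assay on cells (leukaemia cell line, Homo sapiens) for inhibition, read by sulforhodamine B assay, with a stated time of 48 h; a lower number here means a stronger inhibitor of growth, a higher number a weaker inhibitor of growth. Compound 3, at 260 nM, sits within the scatter of both other compounds, so the three cannot be ranked. Compound 4 `O=S(=O)(Nc1ccc(Cl)c(F)c1)c1ccc(-c2cnc(C3CC3)o2)cc1` has not yet been measured. It differs from compound 3 as follows: 4-chloro-3-fluorophenyl in place of 3-chloro-4-fluorophenyl on a sulfonamide nitrogen. The two halogens trade places, and the same atoms are joined differently.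

Three measured steps change this same group: a 1.6-fold lower number from compound 1 to compound 3 (0.20 log units; within the scatter), a 1.7-fold lower number from compound 2 to compound 3 (0.22 log units; within the scatter) and a 1.0-fold higher number from compound 1 to compound 2 (0.01 log units; within the scatter). All three stay within the scatter. None of them tests this exact swap, so the evidence is indirect. Even so, no step beyond the scatter is expected in this assay. The expected change is a 1.2-fold higher number from compound 3 to compound 4 (0.06 log units; within the scatter). For compound 4 the estimated value is 300 nM, with an expected range from 150 nM to 600 nM.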

Compound 4, concentration for 50% growth inhibition: 380 nM
Compound 4: middle estimate off by 1.3-fold (0.10 log units), on the low side, within the range that was stated.
By their numbers in this assay, from the lowest: compounds 3, 4, 1 and 2 (each within the scatter of the next).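

Trading the two halogens gives the first direct test of their placement on the phenyl group on the sulfonamide nitrogen, and in this assay the swap gives a 1.5-fold higher number from compound 3 to compound 4 (0.16 log units; within the scatter). The 4-chloro-3-fluorophenyl group also stays within the scatter of the other two groups at this place, with a 1.1-fold lower number from compound 2 to compound 4 (0.05 log units; within the scatter) and a 1.1-fold lower number from compound 1 to compound 4 (0.04 log units; within the scatter), so all four compounds remain unranked and no arrangement of halogens shown here stands apart. No measurement available here accounts for the differences among these values.

From the compounds shown here alone, all four compounds carry only chloro or fluoro on this phenyl group, so it remains open whether a methoxy group, a nitrile or a carboxylic acid there would give a step beyond the scatter. Going by these compounds, it also remains open how an unsubstituted phenyl group would compare.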